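Compound 3: 6-methylpyridin-3-yl replaces 4-(methylsulfonyl)phenyl

A few compounds are considered here, and "the series" means these few. Any claim that something is new, unique, unknown or untested is made for them only; others in the source may bear on it.

Compound 1 `Nc1ccc(S(=O)(=O)N2CCN(c3ncc(C(O)(C(F)(F)F)C(F)(F)F)cc3-c3ccoc3)CC2)cn1`: < 14 mL.min-1.g-1
Compound 2 `CS(=O)(=O)c1ccc(-c2cc(C(O)(C(F)(F)F)C(F)(F)F)cnc2N2CCN(S(=O)(=O)c3ccc(N)nc3)CC2)cc1`: 32 mL.min-1.g-1

Going by the values given here, in an ADME assay (liver) for metabolic stability, with Liver microsome (Homo sapiens) as the target, using microsomes and NADPH, with a stated time of 30 min, tested at 1 uM (on this read-out higher numbers stand for fast clearance and lower numbers for slow clearance), compound 2 gives 32 mL.min-1.g-1, the only true number so far. Compound 1 stands at < 14 mL.min-1.g-1, which is a limit of the assay and not a number.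

Compound 3 `Cc1ccc(-c2cc(C(O)(C(F)(F)F)C(F)(F)F)cnc2N2CCN(S(=O)(=O)c3ccc(N)nc3)CC2)cn1` has not yet been measured. It departs from compound 2 at a single place: 6-methylpyridin-3-yl in place of 4-(methylsulfonyl)phenyl on an aromatic carbon. In other words, 6-methylpyridin-3-yl stands in place of 4-(methylsulfonyl)phenyl on an aromatic carbon.

Among the compounds with values here, only one measured step bears on this place. With 4-(methylsulfonyl)phenyl in place of furan-3-yl, the data show an at least 2.2-fold higher number from compound 1 to compound 2 (0.35 log units; beyond the scatter). Going by these compounds, that is a single pair, and one end of it is a limit, so its full size is unknown. Compound 3 gives up the same 4-(methylsulfonyl)phenyl, though for a different group, so part of that step may be given back. A modest fall is therefore expected, possibly no larger than the scatter. The expected change is a 1.5-fold lower number from compound 2 to compound 3 (0.16 log units; within the scatter). The estimate in this assay for compound 3 is 22 mL.min-1.g-1, with an expected range from 14 mL.min-1.g-1 to 42 mL.min-1.g-1.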

Compound 3, intrinsic clearance in microsomes: 43 mL.min-1.g-1
Estimate against measurement, compound 3: 2.0-fold (0.29 log units) below; the measured number lies above the stated range.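

In this assay, 6-methylpyridin-3-yl in place of 4-(methylsulfonyl)phenyl gives a 1.3-fold higher number from compound 2 to compound 3 (0.13 log units; within the scatter), so on this aromatic carbon, ortho to a large group, the two groups cannot be told apart, even though they differ in heavy atoms, ring make-up and hydrogen-bond acceptors. 6-methylpyridin-3-yl in place of furan-3-yl gives an at least 3.0-fold higher number from compound 1 to compound 3 (0.48 log units; beyond the scatter), a step beyond the scatter in the same direction as the earlier step to 4-(methylsulfonyl)phenyl. The higher number relative to furan-3-yl therefore does not require the methylsulfonyl group, although this rests on just these two substituents measured against a single partner.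

Going by these compounds, how large either step from furan-3-yl really is stays open, because compound 1 sits at a limit of the assay and not at a number: the limit of < 14 mL.min-1.g-1 in this assay, at which 1 of the 3 values shown sits. Also open is whether a thiophen-3-yl group or an unsubstituted pyridin-3-yl group on this carbon would stay close to compound 1 or instead join compound 2 and compound 3, and so whether ring size or the substituent on the ring goes with the difference.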